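The source may hold more compounds than are shown below. What is called first, only, known or untested is meant among the compounds shown, and "the series" means these compounds.

Measured so far:
Compound 1, `CC(=O)OC/C(=C\c1ccccc1F)C(=O)c1ccccc1`, gives 14600 nM.
Compound 2, `COc1ccc(C(=O)/C(=C/c2ccccc2F)COC(C)=O)cc1`, gives 30000 nM.
Compound 3, `C=C(C(=O)c1ccc(OC)cc1)C(OC(C)=O)c1ccc([N+](=O)[O-])cc1`, gives 6100 nM.

These values come from a functional assay on MCF7 cells (Homo sapiens) for inhibition, read by XTT assay, with a stated time of 48 h; on this read-out higher numbers stand for weaker inhibition and lower numbers for stronger inhibition. Compound 2 differs from compound 1 by methoxy in place of hydrogen on an aromatic carbon, and this change made a 2.1-fold higher number from compound 1 to compound 2 (0.31 log units; beyond the scatter). Compound 4, `C=C(C(=O)c1ccc(OC)cc1OC)C(OC(C)=O)c1ccc([N+](=O)[O-])cc1`, carries the same kind of change against compound 3: methoxy in place of hydrogen on an aromatic carbon. The surroundings differ, however: in compound 2 the methoxy sits para to a large group, whereas in compound 4 it sits ortho to a large group and meta to a methoxy group, so the two changes are of the same kind but not the same. How the core of compound 3 differs from that of compound 1 is not broken down here; their values simply show that compound 3 sits lowest of the three.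

Because the earlier step of a 2.1-fold higher number from compound 1 to compound 2 (0.31 log units; beyond the scatter) was a modest rise, compound 4 is expected to show a step of about a 2.0-fold higher number from compound 3 to compound 4 (0.29 log units; within the scatter) in this assay. Compound 4 is estimated at 12000 nM, within 4000 nM to 40000 nM.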

Compound 4, half-maximal inhibitory concentration: 10400 nM
Estimate against measurement, compound 4: 1.2-fold (0.06 log units) above, and the stated range covers the measured number.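

On the core of compound 3, methoxy in place of hydrogen on an aromatic carbon gave a 1.7-fold higher number from compound 3 to compound 4 (0.23 log units; within the scatter) in this assay. Set beside the earlier step, the new one shows no difference in size: the same change on two cores in this assay, a 2.1-fold higher number (0.31 log units; beyond the scatter) from compound 1 to compound 2 and a 1.7-fold higher number (0.23 log units; within the scatter) from compound 3 to compound 4, 1.2-fold (0.08 log units) apart, within the scatter of two such steps. For the compounds shown here, this shows that the change carried over between these two cores with a similar step, but it does not establish a general rule: there are only two pairs, only the earlier step lies beyond the scatter, and the surroundings are not the same, with the methoxy in compound 4 ortho to a large group and meta to a methoxy group.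

The compounds shown leave open whether an amine, a carboxylic acid or a longer chain such as ethoxy on that aromatic carbon would give a step of similar size. They also leave open whether methoxy on other carbons of that ring would match these two steps.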